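This account rests on a few compounds, and the source may have more. Where it says the series, first, only, none or still open, it means among the compounds named here.

In a functional assay on SK-N-AS cells (Homo sapiens) for antiproliferative activity, with a stated time of 72 h (a lower number here means a stronger inhibitor, a higher number a weaker inhibitor), compound 1 `Cc1cc(C)cc(C(=O)N(CCC(=O)NCc2ccccc2)Cc2ccc(C(=O)NO)cc2)c1` gives 1860 nM, compound 2 `COc1cc(OC)cc(C(=O)N(CCC(=O)NCc2ccccc2)Cc2ccc(C(=O)NO)cc2)c1` gives 9470 nM and compound 3 `CN(C)c1ccc(C(=O)N(CCC(=O)NCc2ccccc2)Cc2ccc(C(=O)NO)cc2)cc1` gives 1420 nM. That places compound 3 at the low end of the set, with a 1.3-fold lower number from compound 1 to compound 3 (0.12 log units; within the scatter) and a 6.7-fold lower number from compound 2 to compound 3 (0.82 log units; beyond the scatter). Compound 4 `COc1ccc(C(=O)N(CCC(=O)NCc2ccccc2)Cc2ccc(C(=O)NO)cc2)cc1` keeps the same core but carries methoxy in place of dimethylamino on an aromatic carbon, para to a large group: methoxy in place of dimethylamino on an aromatic carbon. Among the compounds with values here, no measured step makes this exact swap. Methoxy groups appear among the measured compounds only in compound 2, and the steps touching it are modest: a 5.1-fold higher number from compound 1 to compound 2 (0.71 log units; beyond the scatter) and a 6.7-fold lower number from compound 2 to compound 3 (0.82 log units; beyond the scatter). Within the data shown here, with only that indirect guide, a smaller upward step is expected: a 2.1-fold higher number from compound 3 to compound 4 (0.32 log units; beyond the scatter). Compound 4 is estimated at 3000 nM, with an expected range of 1200 nM to 7500 nM.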

Compound 4, half-maximal inhibitory concentration: 1740 nM
Compound 4: the middle estimate sits 1.7-fold (0.24 log units) above what was measured; the measured number falls inside the stated range.
By their numbers in this assay, from the lowest: compounds 3, 4 and 1 (each within the scatter of the next); then compound 2.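

Swapping dimethylamino for methoxy on this aromatic carbon gives a 1.2-fold higher number from compound 3 to compound 4 (0.09 log units; within the scatter) and so does not separate the two groups. The 4-methoxyphenyl group also stays level with 3,5-dimethylphenyl, showing a 1.1-fold lower number from compound 1 to compound 4 (0.03 log units; within the scatter), while the change from 3,5-dimethoxyphenyl gives a 5.4-fold lower number from compound 2 to compound 4 (0.74 log units; beyond the scatter), so the methoxy group alone does not bring the weak reading of compound 2. No available evidence explains these results.

Going by these compounds, it remains open whether a smaller group such as fluorine, or a carboxylic acid, at this position would shift the number beyond the scatter.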